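Epimer pairs of naphthoquinone glycoside tetra-acetates

The compounds below may be only part of what the source reports. "The series", "measured", "known", "first", "only" and "open" are said of these compounds alone.

Three measured compounds share the same quinone-bearing core, carrying a fully acetylated sugar that differs only in configuration or in one terminal substituent. Compound 1 `CC(=O)OC[C@H]1O[C@@H](OC2=CC(=O)c3ccccc3C2=O)[C@H](OC(C)=O)[C@@H](OC(C)=O)[C@H]1OC(C)=O` gives 13600 nM in a functional assay on MCF7 cells (Homo sapiens) for cytotoxicity, read by sulforhodamine B assay, with a stated time of 72 h; a higher number here means a weaker inhibitor, a lower number a stronger inhibitor. For the measured compounds named here, compound 2 `CC(=O)OC[C@H]1O[C@@H](OC2=CC(=O)c3ccccc3C2=O)[C@H](OC(C)=O)[C@@H](OC(C)=O)[C@@H]1OC(C)=O` gives 4760 nM in this assay, and the step of a 2.9-fold lower number from compound 1 to compound 2 (0.46 log units; beyond the scatter) is the only measured change within the set; it is attributed to configuration alone, since (the fact that compounds 1 and 2 differ only in the configuration as drawn). Compound 3 `CC(=O)O[C@H]1[C@H](OC(C)=O)[C@H](OC2=CC(=O)c3ccccc3C2=O)O[C@@H](C)[C@H]1OC(C)=O` gives 11000 nM in this assay and stands second highest of the three numbers, within the scatter of compound 1 and beyond the scatter of compound 2.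

Compound 4 `CC(=O)O[C@H]1[C@H](OC(C)=O)[C@@H](OC2=CC(=O)c3ccccc3C2=O)O[C@@H](C)[C@H]1OC(C)=O` is not yet measured. Its relation to compound 3 is the two compounds have the same atoms and bonds and differ only in configuration as drawn: 1 of 5 stereo elements differ; a stereocentre at a saturated ring carbon is drawn S in compound 3 and R in compound 4. Going by the values given here, the one comparable step, a single change of configuration, moved the number down by a modest amount, so a step of similar size, toward a lower number, is expected here, though the direction is uncertain with one precedent. For compound 4 the estimate is 6500 nM, within 3000 nM to 14000 nM, an expected step of a 1.7-fold lower number from compound 3 to compound 4 (0.23 log units; within the scatter).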

Compound 4, half-maximal inhibitory concentration: 5020 nM
Compound 4: the middle estimate sits 1.3-fold (0.11 log units) above what was measured; the range from low to high includes it.
By their numbers in this assay, from the lowest: compounds 2 and 4 (each within the scatter of the next); then compounds 3 and 1 (each within the scatter of the next).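

In this assay, changing the configuration at a saturated ring carbon now gives a second measured step, a 2.2-fold lower number from compound 3 to compound 4 (0.34 log units; beyond the scatter), so the earlier 2.9-fold lower number from compound 1 to compound 2 (0.46 log units; beyond the scatter) no longer stands alone. Both pairs move the same way, with the centre drawn R carrying the lower number, and both steps are modest; no pair shown goes against this. The shift can be assigned to configuration alone, because nothing else changes within the pair: the fact that compounds 3 and 4 differ only in the configuration as drawn

The compounds shown leave open whether either step persists when the acetyl groups give way to free hydroxyl groups or when an amine replaces one acetate. They also leave open whether configuration still moves the number when the shared core carries a further substituent, such as a methoxy group.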